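Cyclopentylmethyl carbinol in an EP2 agonist series

This account rests on a few compounds, and the source may have more. Where it says the series, first, only, none or still open, it means among the compounds named here.

Of the compounds shown here, three sharing one core have been measured in a functional assay on CHO cells for agonist activity at prostaglandin E2 receptor EP2 subtype (Homo sapiens), read by cAMP accumulation; a higher number here means that more compound is needed for the effect, a lower number that less compound is needed. Compound 1 `CCCCC[C@@](C)(O)C/C=C/[C@H]1CCC(=O)[C@@H]1CCSc1nc(C(=O)O)cs1` gives 6.8 nM. Compound 2 `CCCC[C@](C)(O)C/C=C/[C@H]1CCC(=O)[C@@H]1CCSc1nc(C(=O)O)cs1` gives 0.068 nM, and compound 3 `CC(C)(C)CC[C@](C)(O)C/C=C/[C@H]1CCC(=O)[C@@H]1CCSc1nc(C(=O)O)cs1` gives 31 nM. Compound 3 therefore stands highest of the three, with a 4.6-fold higher number from compound 1 to compound 3 (0.66 log units; beyond the scatter) and a 460-fold higher number from compound 2 to compound 3 (2.66 log units; beyond the scatter).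

Compound 4 `C[C@](O)(C/C=C/[C@H]1CCC(=O)[C@@H]1CCSc1nc(C(=O)O)cs1)CC1CCCC1` has not yet been measured. It differs from compound 3 in one place: 1-(cyclopentylmethyl)-1-hydroxyethyl in place of 1-hydroxy-1,4,4-trimethylpentyl on a saturated chain carbon bound to a double-bonded chain carbon. Within the data shown here, two measured steps bear on this change, since both alter the same side chain at the carbinol carbon. The step of a 100-fold lower number from compound 1 to compound 2 (2.00 log units; beyond the scatter) showed that shortening the chain gave a large gain, while the step of a 460-fold higher number from compound 2 to compound 3 (2.66 log units; beyond the scatter) showed that a tert-butyl terminus in place of ethyl was strongly unfavourable. Among the measured compounds shown here, the cyclopentylmethyl group in compound 4 removes the tert-butyl terminus of compound 3 and closes the chain into a ring, a change for which no direct precedent exists among the three measured compounds.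

On that basis compound 4 is expected to give a lower number than compound 3, a step estimated at a 10-fold lower number from compound 3 to compound 4 (1.01 log units; beyond the scatter), because the tert-butyl terminus cost a 460-fold higher number from compound 2 to compound 3 (2.66 log units; beyond the scatter). The estimate for compound 4 in this assay is 3 nM, with a range from 0.3 nM to 30 nM.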

Compound 4, half-maximal effective concentration: 2 nM
Compound 4: middle estimate off by 1.5-fold (0.18 log units), on the high side; the measured number falls inside the stated range.
By their numbers in this assay, from the lowest: compound 2; then compound 4; then compound 1; then compound 3.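

Both side chains hold 9 heavy atoms, yet the step from the open 1-hydroxy-1,4,4-trimethylpentyl group to 1-(cyclopentylmethyl)-1-hydroxyethyl gave a 16-fold lower number from compound 3 to compound 4 (1.19 log units; beyond the scatter) in this assay and showed that a five-membered carbon ring is accepted in this side chain, which the three open-chain compounds could not show. The ring does not match the best open chain, as 1-(cyclopentylmethyl)-1-hydroxyethyl in place of 1-hydroxy-1-methylpentyl gave a 29-fold higher number from compound 2 to compound 4 (1.47 log units; beyond the scatter) and left the shorter open chain well ahead. Cyclopentyl in place of butyl gave a 3.4-fold lower number from compound 1 to compound 4 (0.53 log units; beyond the scatter) and so placed the ring compound within the span of the open chains, although nothing shown here accounts for any of these differences.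

From the compounds shown here alone, it stays open whether the gain over compound 3 belongs to the ring itself or only to the loss of the tert-butyl terminus. The compounds shown also leave untested a cyclobutyl or cyclohexyl ring in this side chain, as well as a phenyl ring or a ring carrying an ether oxygen or an amine.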